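A few compounds are considered here, and "the series" means these few. Any claim that something is new, unique, unknown or untested is made for them only; others in the source may bear on it.

Of the compounds shown here, two built on a shared core have been tested in a functional assay on T47D cells (Homo sapiens) for cytotoxicity, read by CCK-8 assay and cell counting, with a stated time of 2 days; a higher number here means a weaker inhibitor, a lower number a stronger inhibitor. Compound 1 `Oc1ccc(-c2cc(-c3ccccc3)nc(-c3ccccc3Cl)c2)cc1` gives 5460 nM in this assay. Compound 2 `Oc1ccc(-c2cc(-c3ccc(Cl)cc3)nc(-c3cccnc3)c2)cc1` gives 29300 nM in this assay. Among the measured compounds shown here, of these two numbers, that of compound 1 is the lower one, and the gap to compound 2 lies beyond the usual scatter; compound 2 differs from compound 1 in more than one place, so no single step joins them, and their two values show only that compound 1 sits at the lower end of what has been measured.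

Compound 3 `Oc1ccc(-c2cc(-c3ccco3)nc(-c3ccccc3Cl)c2)cc1` has not yet been measured. It differs from compound 1 in one place only: furan-2-yl in place of phenyl on an aromatic carbon. For the measured compounds named here, no measured pair shows the effect of such an exchange on this core, so the expectation rests on compound 1 alone. The step from compound 1 to compound 3 is expected to be small, a 1.3-fold higher number from compound 1 to compound 3 (0.11 log units; within the scatter), in either direction or none beyond the scatter. Compound 3 is accordingly estimated at 7000 nM, with a range from 2500 nM to 20000 nM.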

Compound 3, half-maximal inhibitory concentration: 5480 nM
The estimate for compound 3 lay 1.3-fold (0.11 log units) above the measured number, and the stated range covers the measured number.
By their numbers in this assay, from the lowest: compounds 1 and 3 (each within the scatter of the next); then compound 2.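

In this assay, among the compounds shown here, the exchange of phenyl for furan-2-yl on the aromatic carbon next to the ring nitrogen gives a 1.0-fold higher number from compound 1 to compound 3 (0.00 log units; within the scatter), the first single-place step on this core. At this position, with the 2-chlorophenyl and 4-hydroxyphenyl groups unchanged, a five-membered aromatic ring with 1 hetero atom and 5 heavy atoms can therefore stand in place of a six-membered aromatic ring of carbon only with 6 heavy atoms, and the two numbers remain within the scatter of each other, although the entering group carries 1 hydrogen-bond acceptor and the leaving group none. Nothing available explains why the two compounds give matching numbers.

The compounds shown leave open whether this tolerance extends beyond aromatic rings, for instance to a morpholine, a carboxylic acid or a longer alkyl chain on the same carbon. For the compounds shown here, they also leave open whether the furan-2-yl for phenyl exchange would give a similar step on a core carrying something other than the 2-chlorophenyl group, such as a 2-methoxyphenyl group, since this single pair is the only reading of the exchange so far.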